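Swapping Methyl for Nitro on the Benzyl Ring

The source may hold more compounds than are shown below. What is called first, only, known or untested is meant among the compounds shown, and "the series" means these compounds.

Three compounds share one core and differ only in the group on the outer benzyl ring. Compound 1 `COc1cccc(OC)c1OCCNCCOc1ccccc1OCc1ccccc1` carries hydrogen there and gives 0.537 nM in an assay on CHO cells for displacement of a labelled ligand from Alpha-1B adrenergic receptor (Homo sapiens); a higher number here means a weaker inhibitor, a lower number a stronger inhibitor. Compound 2 `COc1cccc(OC)c1OCCNCCOc1ccccc1OCc1ccc(Cl)cc1` carries chloro and gives 1 nM. Compound 3 `COc1cccc(OC)c1OCCNCCOc1ccccc1OCc1ccc(C)cc1` carries methyl and gives 0.251 nM, the lowest number of the three and therefore the strongest inhibitor in this set, since its steps to the others, a 2.1-fold lower number from compound 1 to compound 3 (0.33 log units; beyond the scatter) and a 4.0-fold lower number from compound 2 to compound 3 (0.60 log units; beyond the scatter), are both beyond the scatter, whereas a 1.9-fold higher number from compound 1 to compound 2 (0.27 log units; within the scatter) is not.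

Compound 4 `COc1cccc(OC)c1OCCNCCOc1ccccc1OCc1ccc([N+](=O)[O-])cc1` has not been measured. Its change from compound 3 is nitro in place of methyl on an aromatic carbon. Going by the values given here, no measured step involves nitro, so the bearing of the earlier steps is indirect: replacing methyl by chloro raised the number modestly, and hydrogen sat between the two. Nitro is judged to behave no better than chloro here, so a modestly higher number is expected, a 4.0-fold higher number from compound 3 to compound 4 (0.60 log units; beyond the scatter). Compound 4 is therefore estimated at 1 nM, with a range from 0.3 nM to 3 nM.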

Compound 4, inhibition constant: 0.398 nM
The estimate for compound 4 lay 2.5-fold (0.40 log units) above the measured number; the range from low to high includes it.
By their numbers in this assay, from the lowest: compounds 3, 4, 1 and 2 (each within the scatter of the next, the first and the last beyond it).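

In this assay, the step of a 1.6-fold higher number from compound 3 to compound 4 (0.20 log units; within the scatter) and the step of a 1.3-fold lower number from compound 1 to compound 4 (0.13 log units; within the scatter) both stay within the scatter, so nitro, with three heavy atoms and two hydrogen-bond acceptors, sits level with both methyl and hydrogen at this position. The step of a 2.5-fold lower number from compound 2 to compound 4 (0.40 log units; beyond the scatter) goes beyond the scatter, which shows that two replacements for hydrogen on this ring, nitro and chloro, need not give the same number, and that the methyl-to-chloro step does not predict the methyl-to-nitro step. No measurement here gives a reason for the difference between nitro and chloro.

The compounds shown leave open how an amine, a carboxylic acid or a longer chain would fare at this position. They also leave open whether nitro would give a similar number on another carbon of the same ring.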